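The source may report more compounds than this note shows. Statements on the series, on what has been measured and on what is new or still open speak of the compounds shown alone.

Compound 1 `Cc1nc(-c2ccccc2)c(C(=O)N2CCN(c3cccc(C(F)(F)F)c3)CC2)o1` is the starting point of this account. In a functional assay on HL-60 cells (Homo sapiens) for inhibition, read by MTT assay, with a stated time of 72 h (a higher number here means a weaker inhibitor, a lower number a stronger inhibitor), compound 1 gives 153 nM, the lower of the two numbers reported in this set. Compound 3 `COc1cc(OC)cc(N2CCN(C(=O)c3onc(C)c3-c3ccc(F)cc3)CC2)c1` gives 475 nM in this assay, and the gap between compound 1 and compound 3 lies beyond the usual scatter, so compound 1 is the stronger inhibitor of the two. Compound 2 `CCCc1nc(-c2ccc(OC)cc2)c(C(=O)N2CCN(c3cccc(Cl)c3)CC2)o1` was reported as "not active" (no number reported) in this assay, with no number given. Among these three compounds no pair differs in a single place, so no measured step is available to calibrate the change that follows.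

Compound 4 `CCOc1cccc(N2CCN(C(=O)c3oc(C)nc3-c3ccccc3)CC2)c1` has not yet been measured in this assay. It differs from compound 1 in one place: ethoxy in place of trifluoromethyl on an aromatic carbon. Cut one bond further out, the change reads 3-(trifluoromethyl)phenyl to 3-ethoxyphenyl. With no measured step of this kind in the set, the expectation rests on compound 1 alone, which gives 153 nM in this assay. The step from compound 1 to compound 4 in this assay is expected to be a moderate loss, a 2.6-fold higher number from compound 1 to compound 4 (0.42 log units; beyond the scatter), though a result within the scatter of compound 1 would not surprise. Compound 4 is therefore estimated to give 400 nM in this assay, with a range from 150 nM to 1200 nM.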

Compound 4, half-maximal inhibitory concentration: 151 nM
Compound 4: middle estimate off by 2.6-fold (0.42 log units), on the high side; measured number inside the range.
By their numbers in this assay, from the lowest: compounds 4 and 1 (each within the scatter of the next); then compound 3.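

In this assay, going by these compounds alone, the change from 3-(trifluoromethyl)phenyl to 3-ethoxyphenyl provides the first single-place comparison in this set, giving a 1.0-fold lower number from compound 1 to compound 4 (0.01 log units; within the scatter). Within the data shown here, on an aromatic carbon of this six-membered ring, a group of four heavy atoms with no hydrogen-bond acceptor and a group of three heavy atoms with one hydrogen-bond acceptor therefore cannot be told apart by this measurement, which the earlier compounds could not show. No available evidence explains why the two groups give numbers so close together.

Among these compounds, this single step covers only two groups at one position, so it remains open whether a carboxylic acid, a primary amine or a longer chain such as butoxy would also stay within the scatter of compound 1. Compound 2 and compound 3 each differ from compound 1 in more than one place, so they leave open how much the other parts of the molecule contribute, including the methyl group and the unsubstituted phenyl ring of the shared core.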